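Vinyl in Place of Bromo on the Shared Core

The compounds below may be only part of what the source reports. "The series", "measured", "known", "first", "only" and "open" are said of these compounds alone.

Compound 1, `O=C(Nc1ccc(F)cc1)c1cc(=O)[nH]c2cc(Br)ccc12`, gives only a limit in a functional assay on KYSE-410 cells (Homo sapiens) for antiproliferative activity, read by MTT assay, with a stated time of 72 h; a higher number here means a weaker inhibitor, a lower number a stronger inhibitor: > 20000 nM.
Compound 2, `O=C(Nc1cccc(F)c1)c1cc(=O)[nH]c2cc(Br)ccc12`, gives 7300 nM in this assay.
Compound 3, `O=C(Nc1cccc(C(F)(F)F)c1)c1cc(=O)[nH]c2cc(Br)ccc12`, likewise gives only a limit in this assay: > 20000 nM.

Compound 2 is therefore the only one of the three with a true number; the other two stop at the limit of the limit of > 20000 nM in this assay, at which 2 of the 3 values shown sit. Both measured steps concern the ring on the amide-type nitrogen: an at least 2.7-fold lower number from compound 1 to compound 2 (0.43 log units; beyond the scatter), and an at least 2.7-fold higher number from compound 2 to compound 3 (0.43 log units; beyond the scatter). On these data alone, each is at least modest and reaches beyond the scatter, but each is bounded by a limit, so its full size is unknown.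

Compound 4, `C=Cc1ccc2c(C(=O)Nc3cccc(F)c3)cc(=O)[nH]c2c1`, differs from compound 2 elsewhere, on the shared core: vinyl in place of bromo on an aromatic carbon. Neither measured step touches that position, so they give no direct guide to its effect. Going by the values given here, with no step bearing on the change, the expectation for compound 4 is a number near that of compound 2, with a step of a 1.0-fold lower number from compound 2 to compound 4 (0.02 log units; within the scatter) that stays within the scatter, while allowing a wider band for the unknown. Compound 4 is thus estimated at 7000 nM in this assay, between 2500 nM and 20000 nM.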

Compound 4, half-maximal inhibitory concentration: 13600 nM
Estimate against measurement, compound 4: 1.9-fold (0.29 log units) below; the measured number falls inside the stated range.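

Swapping bromo for vinyl on the shared core gives a 1.9-fold higher number from compound 2 to compound 4 (0.27 log units; within the scatter) in this assay, so compound 2 and compound 4 cannot be told apart in this test. Going by these compounds alone, this is the first information about this position, since every earlier step concerned the ring on the amide-type nitrogen. It shows that one bromine on this aromatic carbon can give way to two carbons carrying a double bond with no difference that stands clear of the usual variation between repeat measurements, and compound 4 keeps a true number, unlike compound 1 and compound 3, which stop at a limit: the limit of > 20000 nM in this assay, at which 2 of the 4 values shown sit.

On these data alone, this reading rests on a single replacement, made with the 3-fluorophenyl ring in place, so whether vinyl would behave the same way alongside the 4-fluorophenyl or trifluoromethyl-bearing rings remains open. Also open, as far as these compounds go, is how an amine, a carboxylic acid or a longer carbon chain would fare at this position, and whether any group there could bring the number clearly lower than in compound 2.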